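This account rests on a few compounds, and the source may have more. Where it says the series, first, only, none or still open, it means among the compounds named here.

Measured so far:
- compound 1 `Cc1ccc(F)c(Nc2ncnc3cc(NC(=O)CCCCCCC(=O)NO)sc23)c1`: 1060 nM
- compound 2 `COc1ccc(Nc2ncnc3cc(NC(=O)CCCCCCC(=O)NO)sc23)c(C)c1`: 1980 nM
- compound 3 `C#Cc1cccc(Nc2ncnc3cc(NC(=O)CCCCCCC(=O)NO)sc23)c1`: 970 nM

In a functional assay on RPMI-8226 cells (Homo sapiens) for antiproliferative activity, read by radiometric assay, with a stated time of 72 h (a lower number here means a stronger inhibitor, a higher number a weaker inhibitor), compound 1 gives 1060 nM, the middle of the three numbers and within the scatter of both others. Compound 4 `COc1ccc(Nc2ncnc3cc(NC(=O)CCCCCCC(=O)NO)sc23)cc1` is the next to be read, and its change from compound 1 is 4-methoxyphenyl in place of 2-fluoro-5-methylphenyl on a nitrogen on an aromatic ring. The nearest measured change is a 1.9-fold higher number from compound 1 to compound 2 (0.27 log units; within the scatter), which also brings in a 4-methoxy group name. The other steps, a 1.1-fold lower number from compound 1 to compound 3 (0.04 log units; within the scatter) and a 2.0-fold lower number from compound 2 to compound 3 (0.31 log units; beyond the scatter), show a narrow span across these groups. For compound 4 the estimated step is a 1.3-fold higher number from compound 1 to compound 4 (0.12 log units; within the scatter), expected to stay within the scatter. Compound 4 is expected at 1400 nM, with an estimated range of 700 nM to 2800 nM.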

Compound 4, half-maximal inhibitory concentration: 1840 nM
For compound 4 the middle estimate is 1.3-fold (0.12 log units) below the measured one; the range from low to high includes it.
By their numbers in this assay, from the lowest: compounds 3, 1, 4 and 2 (each within the scatter of the next, the first and the last beyond it).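

In this assay, among these compounds, hydrogen in place of methyl on an aromatic carbon is the first step confined to a single small group, and it gives a 1.1-fold lower number from compound 2 to compound 4 (0.03 log units; within the scatter). The 4-methoxyphenyl group on the same nitrogen also stays within the scatter of the other two aryl groups, with a 1.7-fold higher number from compound 1 to compound 4 (0.24 log units; within the scatter) and a 1.9-fold higher number from compound 3 to compound 4 (0.28 log units; within the scatter). No measurement shown here offers an explanation for these steps.

Open, going by these compounds, is whether an amine or a carboxylic acid on this aromatic ring would give a step beyond the scatter. Also open, on these data alone, is what a longer chain ending in the hydroxamic acid would do.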